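The compounds below may be only part of what the source reports. "The series", "measured", "known", "first", "only" and "open" are said of these compounds alone.

Going by the values given here, in a functional assay on HT cells (Homo sapiens) for antiproliferative activity, read by fluorescence, with a stated time of 72 h (a lower number here means a stronger inhibitor of growth, a higher number a weaker inhibitor of growth), compound 2 (`CC(C)c1n[nH]c2c(NCc3ccc(-c4ccccn4)cc3)nc(S)nc12`) gives 2760 nM and so holds the higher of the two numbers so far, which makes it the weaker growth inhibitor of the pair. Against it stands compound 1 (`CC(C)c1n[nH]c2c(NCc3ccc(-c4ccccn4)cc3)nc(SCC(O)CO)nc12`) at 21 nM as the only other measured compound. Compound 3 (`CSCCSc1nc(NCc2ccc(-c3ccccn3)cc2)c2[nH]nc(C(C)C)c2n1`) is still unmeasured. It differs from compound 2 by one change (2-(methylsulfanyl)ethyl in place of hydrogen on a sulfur) with 2-(methylsulfanyl)ethyl in place of hydrogen on a sulfur. Among the compounds with values here, one measured step bears on this: a 130-fold higher number from compound 1 to compound 2 (2.12 log units; beyond the scatter) is large and comes with hydrogen in place of 2,3-dihydroxypropyl on a sulfur. Read in reverse, that step shows a chain on this sulfur going with a far lower number. Within the data shown here, the chain of compound 3 is a different one, however, and there is no second example, so a full return to the level of compound 1 cannot be assumed. A large step toward a lower number in this assay is therefore expected. The estimated move is a 46-fold lower number from compound 2 to compound 3 (1.66 log units; beyond the scatter) and would stop a little short of the reverse of the measured step. For compound 3 the expected value is about 60 nM with an estimated range from 15 nM to 300 nM as the likely span.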

Compound 3, concentration for 50% growth inhibition: 975 nM
Beside the measured number, compound 3's estimate is 16-fold (1.21 log units) below it, and the stated range ends below it.
By their numbers in this assay, from the lowest: compound 1; then compound 3; then compound 2.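

In this assay, a chain on this sulfur does not by itself bring the whole of the large gain seen with 2,3-dihydroxypropyl: 2-(methylsulfanyl)ethyl in place of hydrogen gives a 2.8-fold lower number from compound 2 to compound 3 (0.45 log units; beyond the scatter), a step that is beyond the scatter but only modest. The identity of the chain therefore counts as well as its presence, as shown by a 46-fold higher number from compound 1 to compound 3 (1.67 log units; beyond the scatter), a large step that comes with (methylsulfanyl)methyl in place of 1,2-dihydroxyethyl on a saturated chain carbon bound to a sulfur. Nothing measured here gives a reason for this gap between the two chains.

The compounds shown leave open which part of the 2,3-dihydroxypropyl chain goes with the low number, and a chain with a single hydroxyl, such as 2-hydroxyethyl, or a chain ending in an amine or a carboxylic acid, would help to separate the effect of the hydroxyl groups from that of the chain itself. They also leave open whether the sulfur matters, which an oxygen or a nitrogen carrying the same 2,3-dihydroxypropyl chain would test.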